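A Bicyclic Ring Replaces the Dimethylcyclohexyl Group

A few compounds are considered here, and "the series" means these few. Any claim that something is new, unique, unknown or untested is made for them only; others in the source may bear on it.

Two measured compounds share one core and differ only in the saturated ring attached to the aromatic ring of that core. Compound 1 `CCC1CCC(c2nc(C(F)(F)F)ccc2CNC(=O)[C@@H](C)c2ccc(NS(C)(=O)=O)c(F)c2)CC1` carries a 4-ethylcyclohexyl group there, and in an assay on CHO cells for antagonist activity at transient receptor potential cation channel subfamily V member 1 (Homo sapiens), read by FLIPR and calcium flux (on this read-out higher numbers stand for weaker inhibition and lower numbers for stronger inhibition), compound 1 gives 0.2 nM. Compound 2 `C[C@H](C(=O)NCc1ccc(C(F)(F)F)nc1C1CCC(C)(C)CC1)c1ccc(NS(C)(=O)=O)c(F)c1` carries a 4,4-dimethylcyclohexyl group instead, and in this assay compound 2 gives 0.3 nM. The step of a 1.5-fold higher number from compound 1 to compound 2 (0.18 log units; within the scatter) shows that this exchange made no difference that can be separated from noise. Compound 2 holds the higher of the two numbers, but the gap to compound 1 is within the scatter, so the two cannot be ranked.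

Compound 3 `C[C@H](C(=O)NCc1ccc(C(F)(F)F)nc1C1CC2CCC1C2)c1ccc(NS(C)(=O)=O)c(F)c1` takes the change further at the same position: a group of 7 heavy atoms (7 carbon; 2 five-membered non-aromatic rings of carbon only) in place of a group of 8 heavy atoms (8 carbon; one six-membered non-aromatic ring of carbon only), on an aromatic carbon. Within the data shown here, the only measured step that bears on this change is a 1.5-fold higher number from compound 1 to compound 2 (0.18 log units; within the scatter), which altered the same ring without moving the number beyond the scatter. On that basis the step from compound 2 to compound 3 in this assay is expected to be small or absent, a 1.3-fold higher number from compound 2 to compound 3 (0.12 log units; within the scatter). Compound 3 is therefore estimated at 0.4 nM, with a range from 0.15 nM to 1.2 nM.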

Compound 3, inhibition constant: 0.8 nM
The estimate for compound 3 lay 2.0-fold (0.30 log units) below the measured number; the measured number falls inside the stated range.
By their numbers in this assay, from the lowest: compounds 1 and 2 (each within the scatter of the next); then compound 3.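

Among these compounds, exchanging one cyclohexyl group for the other at this position had produced no step that could be separated from noise, but the bicyclic group gives a 2.7-fold higher number from compound 2 to compound 3 (0.43 log units; beyond the scatter) and a 4.0-fold higher number from compound 1 to compound 3 (0.60 log units; beyond the scatter) in this assay. So this position does respond to the ring placed on it, although both steps are modest and compound 3 still gives a low number of 0.8 nM. Nothing shown here explains the rise.

The change alters the ring system and the heavy-atom count together, so these compounds cannot show whether the two-ring arrangement or the loss of a carbon matters more. Going by these compounds, how a plain cyclopentyl group, a piperidine ring or an open tert-butyl group would read at this same position remains open.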